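The source may hold more compounds than are shown below. What is called first, only, known or untested is meant among the compounds shown, and "the series" means these compounds.

Compound 1 `COC(=O)c1cc(N)c(Nc2ccc(C#N)cc2)cc1Oc1c(C)cc(/C=C/C#N)cc1C` and compound 2 `Cc1cc(CCC#N)cc(C)c1Oc1cc(Nc2ccc(C#N)cc2)c(N)cc1S(N)(=O)=O` were both run in an ADME assay on TZM cells (Homo sapiens) for cytotoxicity, read by XTT assay, with a stated time of 4 days; a higher number here means that more compound is tolerated, a lower number that less compound is tolerated. For compound 1, this assay reports only a limit, > 22800 nM. For compound 2, this assay reports 11100 nM. Where compound 1 stands is therefore known only as a boundary: among the two values seen, it sits at the limit itself (the limit of > 22800 nM in this assay, at which 1 of the 2 values shown sits). Compound 3 `Cc1cc(/C=C/C#N)cc(C)c1Oc1cc(Nc2ccc(C#N)cc2)c(N)cc1C(=O)O` departs from compound 1 in a single place: hydrogen in place of methyl on an oxygen next to a carbonyl group. For the measured compounds named here, no measured pair in this set shows what such a change does in this assay, so the size of the step has to be guessed from the two values alone. Compound 3 is expected to move by a step that the limit leaves unreadable from compound 1 to compound 3, that is, no shift beyond the usual scatter. Compound 3 is accordingly estimated at 25000 nM, within a range from 10000 nM to 60000 nM. The measurement that settles this comes next.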

Compound 3, half-maximal cytotoxic concentration: 14900 nM
Compound 3: the middle estimate sits 1.7-fold (0.22 log units) above what was measured; measured number inside the range.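

For the compounds shown here, this is the first measured look at this position: on the oxygen next to a carbonyl group, going from methoxycarbonyl to carboxy gives an at least 1.5-fold lower number from compound 1 to compound 3 (0.18 log units; that floor lies within the scatter) in this assay. Compound 3 gives a defined value of 14900 nM, so the carboxy compound can be placed as a number rather than as a boundary. The real size of the step stays unknown, and the printed floor alone does not show a change beyond the usual scatter, since the reading for compound 1 is only a limit: the limit of > 22800 nM in this assay, at which 1 of the 3 values shown sits.

On these data alone, it remains open how a larger ester, such as an ethyl ester, or a primary amide would stand in this place in this assay. As far as these compounds go, it is also open whether the same change would give a similar step on a core carrying a saturated nitrile chain.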